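The source may report more compounds than this note shows. Statements on the series, on what has been measured and on what is new or still open speak of the compounds shown alone.

Compound 1 `O=Cc1ccc(-c2cn3ccnc3c(-c3ccc4ncn(C5CCCCC5)c4c3)n2)cc1`, compound 2 `CCc1ccc(-c2cn3ccnc3c(-c3ccc4ncn(Cc5ccccc5)c4c3)n2)cc1`, compound 3 `Cc1cccc(-c2cn3ccnc3c(-c3ccc4ncn(Cc5ccccc5)c4c3)n2)c1`.

In a functional assay on SF-268 cells (Homo sapiens) for inhibition, read by sulforhodamine B assay, with a stated time of 48 h, tested at 10 uM (a lower number here means less inhibition, a higher number more inhibition at the concentration tested (going by the name of the read-out)), compound 1 gives 27.1%, compound 2 gives 30.5%, and compound 3 gives 7.22%, the lowest of the three values, beyond the scatter from both others. Among the compounds with values here, the single measured step, a number 23.3 percentage points lower from compound 2 to compound 3 (beyond the scatter), is the only one that touches the group in question. Compound 4 `O=Cc1ccc(-c2cn3ccnc3c(-c3ccc4ncn(Cc5ccccc5)c4c3)n2)cc1` differs from compound 3 in one place: 4-formylphenyl in place of 3-methylphenyl on an aromatic carbon. Compound 1 carries the same 4-formylphenyl group, but differs from compound 4 elsewhere, so its value serves only as a loose pointer. The step of a number 23.3 percentage points lower from compound 2 to compound 3 (beyond the scatter) suggests that leaving 3-methylphenyl should raise the number, so a modest upward step a number 17.8 percentage points higher from compound 3 to compound 4 (beyond the scatter) is expected. Compound 4 is therefore estimated at 25%, in the range 10% to 40%.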

Compound 4, a percentage reported as inhibition, at one concentration (the size of the read-out at that concentration, not a potency): 27.1%
Estimate against measurement, compound 4: 2.1 percentage points below, within the range that was stated.
By their numbers in this assay, from the lowest: compound 3; then compounds 1, 4 and 2 (each within the scatter of the next).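

In this assay, 4-formylphenyl on this aromatic carbon restores a higher number than 3-methylphenyl (a number 19.9 percentage points higher from compound 3 to compound 4 (beyond the scatter)), so the low number of compound 3 does not extend to every substituted phenyl group here. Formyl and ethyl are not told apart (a number 3.4 percentage points lower from compound 2 to compound 4 (within the scatter)), nor are benzyl and cyclohexyl on the aromatic nitrogen (no change at the digits printed from compound 1 to compound 4 (within the scatter)). Nothing at hand explains these numbers.

Open, from the compounds shown here alone, is how an amine or a carboxylic acid in place of formyl would read. Also open, going by these compounds, is whether a 4-methylphenyl group would behave like 3-methylphenyl.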